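The source may report more compounds than this note shows. Statements on the series, on what has been measured and on what is new or still open speak of the compounds shown alone.

Measured in an ADME assay on Vero cells (Chlorocebus sabaeus) for cytotoxicity; on this read-out higher numbers stand for lower toxicity in this test and lower numbers for higher toxicity in this test:
- Compound 1 `O=[N+]([O-])c1ccc(-c2nc3cc(C(F)(F)F)ccc3[nH]2)cc1`: 45000 nM.
- Compound 2 `Fc1cccc(F)c1-c1nc2cc(C(F)(F)F)ccc2[nH]1`: 25000 nM.
- Compound 3 `Cn1c(-c2ccc([N+](=O)[O-])cc2)nc2cc(C(F)(F)F)ccc21`: > 100000 nM, a limit of the assay and not a number.

For compound 3 the read-out in this assay is only a limit: the limit of > 100000 nM in this assay, at which 1 of the 3 values shown sits. Compound 4 `O=[N+]([O-])c1ccc(-c2nc3cc(C(F)(F)F)ccc3n2C2CCCCC2)cc1` differs from it on the aromatic nitrogen, with cyclohexyl in place of methyl on an aromatic nitrogen. Among the compounds with values here, one measured step bears on this nitrogen: an at least 2.2-fold higher number from compound 1 to compound 3 (0.34 log units; beyond the scatter), with methyl in place of hydrogen. Within the data shown here, that step points to a higher number, but its full size is unknown, and no measured compound carries a cyclohexyl. It therefore offers only weak guidance for compound 4. No clear step beyond the scatter is expected, although a somewhat lower number than the limit of the methyl compound remains possible. The expected change is an at least 1.2-fold lower number from compound 3 to compound 4 (0.09 log units; that floor lies within the scatter). The estimate for compound 4 is 80000 nM, with an expected range from 30000 nM to 200000 nM.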

Compound 4, half-maximal cytotoxic concentration: > 100000 nM
Compound 4 gave a limit, no number; the forecaster's own chance of this, stated with the estimate: 45%; middle value at least 1.2-fold (0.09 log units) away from the limit.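

In this assay compound 4 gives > 100000 nM, which is a limit of the assay and not a number. Cyclohexyl in place of hydrogen on the aromatic nitrogen gives an at least 2.2-fold higher number from compound 1 to compound 4 (0.34 log units; beyond the scatter), so the rise first seen with methyl is not confined to that one group and also appears with a six-membered non-aromatic ring of carbon only. Whether cyclohexyl and methyl differ from each other cannot be read, because compound 3 and compound 4 both end at a limit: the limit of > 100000 nM in this assay, at which 2 of the 4 values shown sit.

On these data alone, whether an amine or a carboxylic acid on this nitrogen would also reach that limit remains open. So does whether replacing the hydrogen on this nitrogen in compound 2 would give a higher number as well.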